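Triazole-linked quinoline nucleosides: effect of a methoxy removal

The source may hold more compounds than are shown below. What is called first, only, known or untested is meant among the compounds shown, and "the series" means these compounds.

Four compounds share a nucleoside portion joined through a triazole to a quinuclidine-bearing quinoline fragment. Compound 1 `COc1ccc2nccc([C@H](O)[C@H]3CC4CCN3CC4c3cn([C@H]4C[C@H](n5cc(C)c(=O)[nH]c5=O)O[C@@H]4CO)nn3)c2c1` and compound 2 `Cc1cn([C@H]2C[C@H](n3cc(C4CN5CCC4C[C@@H]5[C@@H](O)c4ccnc5ccccc45)nn3)[C@@H](CO)O2)c(=O)[nH]c1=O` carry one core; compound 3 `C=CC1CN2CCC1C[C@H]2[C@H](OCc1cn([C@H]2C[C@H](n3cc(C)c(=O)[nH]c3=O)O[C@@H]2CO)nn1)c1ccnc2ccc(OC)cc12` and compound 4 `C=CC1CN2CCC1C[C@H]2[C@H](OCc1cn([C@H]2C[C@H](n3cc(C)c(=O)[nH]c3=O)O[C@@H]2CO)nn1)c1ccnc2ccccc12` carry another, and the difference between the two cores is not broken down here. In a functional assay on KB cells (Homo sapiens) for inhibition (on this read-out higher numbers stand for an effect only at larger amounts of compound and lower numbers for an effect already at smaller amounts), compound 1 gives 12 ug/mL, and compound 2 gives 21 ug/mL. The change from compound 1 to compound 2 is hydrogen in place of methoxy on an aromatic carbon, and it produced a 1.8-fold higher number from compound 1 to compound 2 (0.24 log units; within the scatter). Compound 3, on the second core, gives 2.1 ug/mL in this assay, the lowest of the three numbers recorded so far. Compound 4 is the same change made on the second core, (hydrogen in place of methoxy on an aromatic carbon); the place is described in identical words for both pairs, so it is the same change. Resting on the step from compound 1 to compound 2, which stayed within the scatter, compound 4 is expected to show a step of about a 1.8-fold higher number from compound 3 to compound 4 (0.26 log units; within the scatter) in this assay. The estimate for compound 4 is therefore 3.8 ug/mL, between 1.5 ug/mL and 9 ug/mL.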

Compound 4, concentration for half-maximal effect: > 100 ug/mL
Compound 4: a limit, no number; the forecaster's own chance of this, stated with the estimate: 3%; at least 26-fold (1.42 log units) between middle value and limit.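

In this assay compound 4 gives > 100 ug/mL, which is a limit of the assay and not a number. Hydrogen in place of methoxy gave an at least 47-fold higher number from compound 3 to compound 4 (1.67 log units; beyond the scatter), so in these two pairs the change does not carry over from one core to the other with the same effect: the same change on two cores in this assay, a 1.8-fold higher number (0.24 log units; within the scatter) from compound 1 to compound 2 and an at least 47-fold higher number (1.67 log units; beyond the scatter) from compound 3 to compound 4, at least 27-fold (1.43 log units) apart, beyond the scatter of two such steps What this does not show is which feature of the two cores goes with the difference, and the full size of the second step remains unknown, as it rests on a limit: the limit of > 100 ug/mL in this assay, at which 1 of the 4 values shown sits.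

The compounds shown leave open whether another group on the same aromatic carbon, such as ethoxy, hydroxyl or an amine, would keep the number of compound 3 or move towards that of compound 4. From the compounds shown here alone, they also do not separate the parts of the difference between the two cores, so it remains open which part goes with the large step.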